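Replacing a methyl on the aromatic nitrogen of compound 2

The source may report more compounds than this note shows. Statements on the series, on what has been measured and on what is new or still open speak of the compounds shown alone.

For the measured compounds named here, in a functional assay on the whole organism with Rattus norvegicus as the target (on this read-out lower numbers stand for an effect already at smaller amounts and higher numbers for an effect only at larger amounts of compound), compound 2 (`COc1cc(N(C)C)c(Cl)cc1C(=O)NC1CCN(Cc2ccccc2)C1`) gives 0.12 mg/kg and holds the lowest number so far, ahead of compound 3 (`COc1cc(N(C)C)c(Cl)cc1C(=O)NC1CCN(C2CCCCC2)C1`) at 1 mg/kg and compound 1 (`CCCCN(CCNC(=O)c1cc(Cl)c(N)cc1OC)Cc1ccc(Cl)cc1`) at 20 mg/kg at the top. Compound 4 (`COc1cc(N(C)C(=O)C(F)(F)F)c(Cl)cc1C(=O)NC1CCN(Cc2ccccc2)C1`) has (trifluoromethyl)carbonyl in place of methyl on a nitrogen on an aromatic ring. Going by the values given here, the only measured step is an 8.3-fold higher number from compound 2 to compound 3 (0.92 log units; beyond the scatter) and it concerns an amine nitrogen in a ring, so no measurement yet covers this nitrogen. Using that step as a rough guide to size, the expected change in this assay is a 5.8-fold higher number from compound 2 to compound 4 (0.77 log units; beyond the scatter) with wide uncertainty. For compound 4 the estimated value is 0.7 mg/kg (expected range 0.12 mg/kg to 5 mg/kg).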

Compound 4, dose for half-maximal effect: 0.3 mg/kg
Estimate against measurement, compound 4: 2.3-fold (0.37 log units) above; measured number inside the range.
By their numbers in this assay, from the lowest: compound 2; then compound 4; then compound 3; then compound 1.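

For the compounds shown here, this is the first measurement at the nitrogen on an aromatic ring. In this assay, putting (trifluoromethyl)carbonyl in place of methyl gives a 2.5-fold higher number from compound 2 to compound 4 (0.40 log units; beyond the scatter), so a group of 6 heavy atoms instead of 1 is tolerated here at a modest cost. No measurement at hand explains this step.

Still open, from the compounds shown here alone, is how much of the step belongs to the carbonyl and how much to the trifluoromethyl, which an acetyl group on this nitrogen would help separate. Going by these compounds, a plain hydrogen or an ethyl group here also remains unexplored.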